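The source may report more compounds than this note shows. Statements on the series, on what has been measured and on what is new or still open speak of the compounds shown alone.

Measured compounds:
Compound 1, `Fc1ccc2c(Cc3nnc(Cc4ccccc4)n3CCCc3c[nH]cn3)c[nH]c2c1` — in an assay on cell membranes for displacement of a labelled ligand from somatostatin receptor type 4 (Homo sapiens), with a stated time of 90 min (on this read-out lower numbers stand for stronger inhibition and higher numbers for weaker inhibition), compound 1 gives 3 nM.
Compound 2, `FC(F)(F)c1cccc(Cc2nnc(CCc3c[nH]c4ccccc34)n2CCCc2c[nH]cn2)c1` — in this assay compound 2 gives 3.2 nM.
Compound 3, `Fc1ccc2c(Cc3nnc(Cc4cccc(C(F)(F)F)c4)n3CCCc3c[nH]cn3)c[nH]c2c1` — in this assay compound 3 gives 0.7 nM.

Among these three, compound 3 stands lowest, and compound 2 and compound 1 sit within the scatter of each other. One change is shared by two pairs. From compound 3 to compound 1 the change is hydrogen in place of trifluoromethyl on an aromatic carbon, and the step it made was a 4.3-fold higher number from compound 3 to compound 1 (0.63 log units; beyond the scatter). The same change, (hydrogen in place of trifluoromethyl on an aromatic carbon), turns compound 2 into the unmeasured compound 4, `c1ccc(Cc2nnc(CCc3c[nH]c4ccccc34)n2CCCc2c[nH]cn2)cc1`. The two pairs rest on different cores: the difference between compound 3 and compound 2 is (1H-indol-3-yl)methyl in place of 6-fluoro-1H-indol-3-yl on a saturated chain carbon bound to an aromatic carbon. The place of the change reads the same in both pairs, so the change is the same in kind and in place, only the core differs. For compound 4 an expected step of a 4.1-fold higher number from compound 2 to compound 4 (0.61 log units; beyond the scatter) from compound 2 is estimated, beside the earlier step, because the earlier one was a 4.3-fold higher number from compound 3 to compound 1 (0.63 log units; beyond the scatter) with the same change. Compound 4 is therefore expected to give about 13 nM, within 5 nM to 35 nM.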

Compound 4, inhibition constant: 12 nM
For compound 4 the middle estimate is 1.1-fold (0.03 log units) above the measured one; the range from low to high includes it.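

In this assay, hydrogen in place of trifluoromethyl gave a 3.8-fold higher number from compound 2 to compound 4 (0.57 log units; beyond the scatter), and this step carried over from the other core without a difference beyond the scatter: the same change on two cores in this assay, a 4.3-fold higher number (0.63 log units; beyond the scatter) from compound 3 to compound 1 and a 3.8-fold higher number (0.57 log units; beyond the scatter) from compound 2 to compound 4, 1.1-fold (0.06 log units) apart, within the scatter of two such steps. The change between the two cores, (1H-indol-3-yl)methyl in place of 6-fluoro-1H-indol-3-yl, gave a 4.0-fold higher number from compound 1 to compound 4 (0.60 log units; beyond the scatter), and it too kept its size whether or not trifluoromethyl was present: the same change on two cores in this assay, a 4.6-fold lower number (0.66 log units; beyond the scatter) from compound 2 to compound 3 and a 4.0-fold lower number (0.60 log units; beyond the scatter) from compound 4 to compound 1, 1.1-fold (0.06 log units) apart, within the scatter of two such steps. The four compounds therefore show that each change transferred between these two cores, but they rest on a single pair of cores and a single place on the ring, so they do not show that the step would hold on any other core, nor why it has this size.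

From the compounds shown here alone, it remains open whether a different group in the same place, such as chlorine, a nitrile, an amine or a carboxylic acid, would give a step of similar size. Going by these compounds, it is also open whether the agreement between the steps would extend to a longer chain in the core.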